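Mirror Image of a Cytotoxic Lactone, Before Measurement

A few compounds are considered here, and "the series" means these few. Any claim that something is new, unique, unknown or untested is made for them only; others in the source may bear on it.

Two unsaturated lactones have so far been tested in a functional assay on A2780 cells (Homo sapiens) for cytotoxicity, read by MTT assay, with a stated time of 24 h; on this read-out lower numbers stand for stronger inhibition and higher numbers for weaker inhibition. Compound 1 `CCCCC[C@H](CCC[C@@H]1CC=CC(=O)O1)OC` gives 14400 nM. Compound 2 `CCCCC[C@@H](C[C@H](O)C[C@@H]1CC=CC(=O)O1)OC` gives 35400 nM, the higher of the two numbers, beyond the scatter from compound 1. Compound 3 `CCCCC[C@H](C[C@@H](O)C[C@H]1CC=CC(=O)O1)OC` is not yet measured; it differs from compound 2 as follows: the two compounds have the same atoms and bonds and differ only in configuration as drawn: 3 of 3 stereo elements differ (all stereocentres are inverted: mirror images); a stereocentre at a saturated chain carbon is drawn S in compound 2 and R in compound 3; a stereocentre at a saturated chain carbon is drawn S in compound 2 and R in compound 3; a stereocentre at a saturated ring carbon is drawn S in compound 2 and R in compound 3. For the measured compounds named here, no step between measured compounds is available, so nothing here shows how inverting every stereocentre shifts this read-out. Compound 3 is therefore expected to land close to compound 2, with an estimated step of a 1.0-fold lower number from compound 2 to compound 3 (0.00 log units; within the scatter), within the scatter. The estimate for compound 3 is 35000 nM, ranging from 8000 nM to 150000 nM.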

Compound 3, half-maximal inhibitory concentration: 28900 nM
The estimate for compound 3 lay 1.2-fold (0.08 log units) above the measured number; low and high end bracket the measured number.
By their numbers in this assay, from the lowest: compounds 1, 3 and 2 (each within the scatter of the next, the first and the last beyond it).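

In this assay, inverting all three stereocentres gives a 1.2-fold lower number from compound 2 to compound 3 (0.09 log units; within the scatter), so this pair of mirror images cannot be told apart on this read-out. The comparison is a clean one, with only a single kind of change in play: the fact that compounds 2 and 3 differ only in the configuration as drawn

Only the complete inversion is shown here, so whether inverting just one stereocentre would shift the number remains open. Also open, on these data alone, is how an amine or a longer chain on the shared core would behave in this assay.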